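A sulfonyl replaces the aryl group: lower cytotoxicity expected

This account rests on a few compounds, and the source may have more. Where it says the series, first, only, none or still open, it means among the compounds named here.

Going by the values given here, in an ADME assay on HEp-2 cells (Homo sapiens) for cytotoxicity, read by CCK-8 assay, with a stated time of 6 days (on this read-out lower numbers stand for higher toxicity in this test and higher numbers for lower toxicity in this test), compound 1 `NCCNc1cc(N2CCN(c3ccccc3Cl)CC2)nc2ccccc12` gives 20800 nM, the only plain number in this set. The other two values are limits of the assay. Compound 2 `NCCNc1cc(N2CCN(C(=O)C3(c4ccccc4)CC3)CC2)nc2ccccc12` sits at the limit > 100000 nM. Compound 3 `CS(=O)(=O)N1CCN(c2cc(NCCN)c3ccccc3n2)CC1` likewise sits at the limit > 100000 nM. Compound 4 `NCCNc1cc(N2CCN(S(=O)(=O)c3ccccc3)CC2)nc2ccccc12` differs from compound 1 by phenylsulfonyl in place of 2-chlorophenyl on an amine nitrogen in a ring. Among the compounds with values here, the one measured step that bears on this change is an at least 4.8-fold higher number from compound 1 to compound 3 (0.68 log units; beyond the scatter), whose full size stays unknown because of the limit of > 100000 nM in this assay, at which 2 of the 3 values shown sit. Since a sulfonyl enters here as well, a step in the same direction is expected, quite possibly ending at the same limit. Compound 4 is therefore expected to give 70000 nM, within 25000 nM to 200000 nM, which means an expected step of a 3.4-fold higher number from compound 1 to compound 4 (0.53 log units; beyond the scatter).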

Compound 4, half-maximal cytotoxic concentration: 20500 nM
Compound 4: the middle estimate sits 3.4-fold (0.53 log units) above what was measured, and the stated range ends above it.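

In this assay, a sulfonyl on this ring nitrogen does not by itself shift the read-out: phenylsulfonyl in place of 2-chlorophenyl gives a 1.0-fold lower number from compound 1 to compound 4 (0.01 log units; within the scatter). What the sulfonyl sulfur carries matters instead, since phenyl in place of methyl there gives an at least 4.8-fold lower number from compound 3 to compound 4 (0.68 log units; beyond the scatter). The full size of that second step stays unknown because one end of it is a limit: the limit of > 100000 nM in this assay, at which 2 of the 4 values shown sit.

As far as these compounds go, it stays open how a longer alkyl chain on the sulfonyl sulfur would read in this assay. From the compounds shown here alone, the effect of an amine or a carboxylic acid on the phenyl ring of compound 4 is equally open.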